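Nitro in Place of Chloro on Two Related Cores

The source may hold more compounds than are shown below. What is called first, only, known or untested is meant among the compounds shown, and "the series" means these compounds.

Measured in an ADME assay on NIH3T3 cells (Mus musculus) for cytotoxicity, read by MTT assay, with a stated time of 24 h; a lower number here means a stronger inhibitor, a higher number a weaker inhibitor:
compound 1 `Cc1ccc(-c2nnc(N3CCN(C(=O)CN4CCN(c5ccc(Cl)cc5)CC4)CC3)nc2-c2ccc(C)cc2)cc1` gives 567000 nM.
compound 2 `Cc1ccc(-c2nnc(N3CCN(C(=O)CN4CCN(c5ccc([N+](=O)[O-])cc5)CC4)CC3)nc2-c2ccc(C)cc2)cc1` gives only a limit, > 844000 nM.
compound 3 `COc1ccc(-c2nnc(N3CCN(C(=O)CN4CCN(c5ccc(Cl)cc5)CC4)CC3)nc2-c2ccc(OC)cc2)cc1` gives only a limit, > 814000 nM.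

The change from compound 1 to compound 2 is nitro in place of chloro on an aromatic carbon; it gave an at least 1.4-fold higher number from compound 1 to compound 2 (0.17 log units; that floor lies within the scatter), and the number for compound 2 sits at the limit of > 844000 nM in this assay, at which 1 of the 3 values shown sits. The number for compound 3 sits at the limit of > 814000 nM in this assay, at which 1 of the 3 values shown sits. How the core of compound 3 differs from the core of compound 1 is not broken down here. Compound 4 `COc1ccc(-c2nnc(N3CCN(C(=O)CN4CCN(c5ccc([N+](=O)[O-])cc5)CC4)CC3)nc2-c2ccc(OC)cc2)cc1` is not yet measured; it differs from compound 3 by nitro in place of chloro on an aromatic carbon, the same change as before, at the same place.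

Compound 4 is expected to give about 1000000 nM in this assay, between 600000 nM and 2500000 nM, most likely again only a limit. That expectation rests on compound 1 and compound 2, whose step was an at least 1.4-fold higher number from compound 1 to compound 2 (0.17 log units; that floor lies within the scatter), and on compound 3 already sitting at a limit. The step expected is a step that the limit leaves unreadable from compound 3 to compound 4.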

Compound 4, half-maximal inhibitory concentration: > 801000 nM
Compound 4 gave a limit, no number (the forecaster's own chance of this, stated with the estimate: 85%); the middle value lies beyond the limit too.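

In this assay, compound 3 and compound 4 each gave only a limit rather than a number, and the step between them cannot be read. From the compounds shown here alone, how far nitro in place of chloro shifts the number on this core stays open.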